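The source may hold more compounds than are shown below. What is called first, only, known or untested is meant among the compounds shown, and "the series" means these compounds.

Working notes on the sulfonamide series. All three measured compounds share one core and differ only in the aryl group attached to the sulfonamide. Compound 1 `CCOC(=O)c1oc2ccc(NS(=O)(=O)c3ccc(Cl)cc3)cc2c1C` gives 44000 nM in a functional assay on MDA-MB-468 cells (Homo sapiens) for antiproliferative activity, read by MTT assay, with a stated time of 72 h; a lower number here means a stronger inhibitor, a higher number a weaker inhibitor. Compound 2 `CCOC(=O)c1oc2ccc(NS(=O)(=O)c3ccc(Br)cc3)cc2c1C` gives 26400 nM in this assay. Compound 3 `CCOC(=O)c1oc2ccc(NS(=O)(=O)c3cccc(C(F)(F)F)c3)cc2c1C` gives 28900 nM in this assay. Going by the values given here, the one single-point step among them, a 1.7-fold lower number from compound 1 to compound 2 (0.22 log units; within the scatter), exchanges one halogen for another on an aromatic carbon and does not rise above the scatter. Compound 3 sits within the scatter of both compound 2 and compound 1, so the three numbers cannot be told apart.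

Compound 4 `CCOC(=O)c1oc2ccc(NS(=O)(=O)c3cccc([N+](=O)[O-])c3)cc2c1C` has not yet been measured in this assay. It differs from compound 3 by nitro in place of trifluoromethyl on an aromatic carbon. Among the compounds with values here, no measured step exchanges a trifluoromethyl for a nitro, so nothing bears directly on this change; the only step in hand, from compound 1 to compound 2, is a halogen exchange that stays within the scatter, and every exchange of the aryl substituent so far has left the numbers together. The step from compound 3 to compound 4 is therefore expected to be a 1.0-fold higher number from compound 3 to compound 4 (0.02 log units; within the scatter), with no direction beyond the scatter. For compound 4 the expected value in this assay is 30000 nM, with a range from 12000 nM to 75000 nM.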

Compound 4, half-maximal inhibitory concentration: 30100 nM
Compound 4: the middle estimate sits 1.0-fold (0.00 log units) below what was measured, within the range that was stated.
By their numbers in this assay, from the lowest: compounds 2, 3, 4 and 1 (each within the scatter of the next).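

In this assay, trifluoromethyl and nitro on this aromatic carbon, meta to a large group, cannot be told apart: the exchange gives a 1.0-fold higher number from compound 3 to compound 4 (0.02 log units; within the scatter), even though the entering group carries hydrogen-bond acceptors and the leaving group carries none. Going by these compounds alone, this is the first exchange at this position, and it extends the flat picture beyond the halogen exchange seen earlier. The replacements of a whole aryl group, which move from a 4-substituted to a 3-substituted phenyl and also change the substituent, give a 1.1-fold higher number from compound 2 to compound 4 (0.06 log units; within the scatter) and a 1.5-fold lower number from compound 1 to compound 4 (0.16 log units; within the scatter), so neither 3-nitrophenyl in place of 4-bromophenyl nor 3-nitrophenyl in place of 4-chlorophenyl separates the compounds. No measurement of any property of these groups is available to bear on this result.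

The compounds shown leave open whether an amine or a carboxylic acid on this same aromatic carbon would produce a step beyond the scatter. They also leave open whether any change outside the aryl group, such as a carboxylic acid in place of the ester on the shared core, would move the numbers at all.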